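Furan Replaces Pyridine on the Amide of an Arylpiperazine

This account rests on a few compounds, and the source may have more. Where it says the series, first, only, none or still open, it means among the compounds named here.

Of the compounds shown here, two sharing one core have been measured in a functional assay for antagonist activity at Adrenergic receptor alpha-1 (Rattus norvegicus); a higher number here means weaker binding, a lower number tighter binding. Compound 1 `Cc1ccc(N2CCN(CCNC(=O)c3cc4ccccc4o3)CC2)c(C)c1` gives 43.7 nM. Compound 2 `Cc1ccc(N2CCN(CCNC(=O)c3ccncc3)CC2)c(C)c1` gives 85.1 nM. Going by the values given here, compound 2 therefore holds the higher of the two numbers, but the only step connecting them, a 1.9-fold higher number from compound 1 to compound 2 (0.29 log units; within the scatter), is within the scatter, so the two values cannot be told apart with confidence.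

Compound 3 `Cc1ccc(N2CCN(CCNC(=O)c3ccco3)CC2)c(C)c1` is not yet measured. It differs from compound 2 in one place: furan-2-yl in place of pyridin-4-yl on a carbonyl carbon. Among the compounds with values here, the furan-2-yl that enters is the five-membered part of the 1-benzofuran-2-yl that compound 1 carries on the same carbonyl carbon, so the step from compound 1 to compound 2 is the one measured step that bears on this change, and it was within the scatter.

On that basis compound 3 is expected to land close to compounds 1 and 2, with the estimated step of a 1.4-fold lower number from compound 2 to compound 3 (0.15 log units; within the scatter) not beyond the scatter. The estimate for compound 3 is 60 nM, with a likely range from 20 nM to 200 nM.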

Compound 3, dissociation constant: 19.1 nM
For compound 3 the middle estimate is 3.1-fold (0.50 log units) above the measured one; the whole stated range lies above it.
By their numbers in this assay, from the lowest: compound 3; then compounds 1 and 2 (each within the scatter of the next).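

In this assay, the group on this carbonyl carbon now makes a difference that can be read, since replacing pyridin-4-yl with furan-2-yl gives a 4.5-fold lower number from compound 2 to compound 3 (0.65 log units; beyond the scatter), whereas the first two compounds could not be told apart. The furan-2-yl group also does better than the 1-benzofuran-2-yl group that contains it, with a 2.3-fold lower number from compound 1 to compound 3 (0.36 log units; beyond the scatter), so keeping only the five-membered part of that group gives the lowest number of the three, and both steps are modest in size. Nothing available for these compounds accounts for why furan-2-yl gives the tighter binding.

On these data alone, it remains open whether this result is specific to the furan-2-yl group or would also hold for another five-membered ring on the same carbonyl carbon, such as thiophen-2-yl or furan-3-yl, or for an open-chain group such as cyclopropyl's unringed relative, isopropyl. All three compounds also share the same core and the same two-carbon-free amide link to it, so the compounds shown cannot tell whether furan-2-yl would keep its lead with a longer chain in that link.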